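This account rests on a few compounds, and the source may have more. Where it says the series, first, only, none or still open, it means among the compounds named here.

Measured so far in a functional assay on MCF7 cells (Homo sapiens) for cytotoxicity, read by MTT assay, with a stated time of 6 days; on this read-out higher numbers stand for an effect only at larger amounts of compound and lower numbers for an effect already at smaller amounts:
- compound 1, `COC(=O)c1c(-c2ccc(OC)cc2)oc2ccccc2c1=O`: > 25 ug/mL
- compound 2, `COC(=O)c1c(-c2ccc([N+](=O)[O-])cc2)oc2ccccc2c1=O`: > 25 ug/mL
- compound 3, `COC(=O)c1c(-c2ccc(O)cc2)oc2ccccc2c1=O`: > 25 ug/mL

The value of compound 1 is a limit of the assay, not a number. The same holds for compound 2. The same holds for compound 3. All three values sit at the limit of > 25 ug/mL in this assay, at which 3 of the 3 values shown sit. Compound 1 and compound 2 share a core and differ by nitro in place of methoxy on an aromatic carbon. From compound 1 to compound 3 the change is hydrogen in place of methyl on an oxygen on an aromatic ring, and the step it made is a step that the two limits leave unreadable from compound 1 to compound 3.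

Compound 4, `O=C(O)c1c(-c2ccc([N+](=O)[O-])cc2)oc2ccccc2c1=O`, is not yet measured. It arises from compound 2 by hydrogen in place of methyl on an oxygen next to a carbonyl group. This is the same kind of change as that from compound 1 to compound 3, but not the same: there the place was on an oxygen on an aromatic ring whose other neighbours are an aromatic carbon, here it is on an oxygen next to a carbonyl group whose other neighbours are a carbonyl carbon. The step from compound 2 to compound 4 is expected to be a step that the limit leaves unreadable from compound 2 to compound 4, because every measured value, compound 2 included, sits at the limit of > 25 ug/mL in this assay, at which 3 of the 3 values shown sit, and no number is known. Compound 4 is therefore estimated at 40 ug/mL in this assay.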

Compound 4, concentration for half-maximal effect: > 25 ug/mL
Compound 4 ended at the assay's limit; the forecaster's own chance of this, stated with the estimate: 80%; the middle value is on the limit's open side.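

No new step can be read between compound 2 and compound 4, as the results for both in this assay are limits and not numbers: the limit of > 25 ug/mL in this assay, at which 4 of the 4 values shown sit.
The compounds shown leave open whether any change to the shared core would give a measurable value in this assay, and how large a step between them would be.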